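Swapping an Amide Chain for a Benzyl Carbamate

The source may report more compounds than this note shows. Statements on the series, on what has been measured and on what is new or still open speak of the compounds shown alone.

Measured compounds:
- compound 1, `CCCCCC(=O)N1CCN(c2nc(N)c3cc(OC)c(OC)cc3n2)[C@@H]2CCCC[C@@H]21`, 7.99
- compound 2, `CCCN(CCC)c1nc(N2CCN(C(=O)c3ccco3)[C@H]3CCCC[C@H]32)nc2cc(OC)c(OC)cc12`, 7.86

Of the compounds shown here, two have been tested in a functional assay (strain Wistar) for antagonist activity at Alpha-1B adrenergic receptor (Rattus norvegicus), with a stated time of 30 min, in the presence of a further agent that is not named here; a higher number here means a more potent compound, by a factor of ten per unit of this negative logarithm, a lower number a less potent compound. Compound 1 gives 7.99 and compound 2 gives 7.86; the two numbers lie within the usual scatter of each other, so nothing separates them beyond what repeat measurements would show. Compound 1 therefore stands at the top of the two numbers only nominally, with compound 2 essentially level with it.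

The unmeasured compound 3, `COc1cc2nc(N3CCN(C(=O)OCc4ccccc4)[C@H]4CCCC[C@H]43)nc(N)c2cc1OC`, shares the core of compound 1 and differs from it in one place: benzyloxy in place of pentyl on a carbonyl carbon. Read one bond further out, the change is pentylcarbonyl to benzyloxycarbonyl. Among the measured compounds shown here, no pair of measured compounds shows this change, and compound 2 differs from compound 1 in more than one place, so no measured step informs the direction.

With nothing to point either way, compound 3 is expected to sit close to compound 1, the step of a number 0.09 log units lower from compound 1 to compound 3 (within the scatter) being estimated as lying within the scatter. Compound 3 is expected to give about 7.9 in this assay, estimated between 7.2 and 8.6.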

Compound 3, negative logarithm of the antagonist equilibrium constant: 8.77
Compound 3: the middle estimate sits 0.87 log units below what was measured; the whole stated range lies below it.
By their numbers in this assay, from the lowest: compounds 2 and 1 (each within the scatter of the next); then compound 3.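

In this assay, the position on the carbonyl carbon bound to the amide-type nitrogen in a ring now has its first readable step: benzyloxy in place of pentyl gives a number 0.78 log units higher from compound 1 to compound 3 (beyond the scatter), so the read-out responds to what is attached here, and this change raises it. The entering group differs from pentyl in more than one way at once, holding both an oxygen and a six-membered aromatic ring of carbon only, so this single step cannot show which of the two goes with the rise. No measurement bears on why the number moved.

A pentyloxy chain on the same carbonyl carbon would keep the oxygen without the ring, while a phenethyl group would keep the ring without the oxygen, and these two would begin to pull the parts of the change apart. On these data alone, it also remains open whether the same swap gives a similar step when the rest of the molecule differs from the shared core of compound 1 and compound 3, or at other adrenergic receptors.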